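This account rests on a few compounds, and the source may have more. Where it says the series, first, only, none or still open, it means among the compounds named here.

Measured so far:
compound 1 `O=C(O)[C@@H]1NCC=C[C@H]1O` — 14%
compound 2 `O=C(O)[C@H]1NC[C@@H](O)[C@@H](O)[C@@H]1O` — 28%

In an assay on isolated protein for inhibition of cytosolic endo-beta-N-acetylglucosaminidase (Homo sapiens), tested at 1000 uM (on this read-out lower numbers stand for less inhibition and higher numbers for more inhibition at the one concentration tested (going by the name of the read-out)), compound 2 gives 28% and compound 1 gives 14%. Among the compounds with values here, compound 2 thus stands highest of the two numbers, and its only neighbour, compound 1, sits lower by a gap beyond the usual scatter.

Compound 3 `O=C(O)[C@@H]1NC[C@H](O)[C@@H](O)[C@@H]1O` differs from compound 2 as follows: the two compounds have the same atoms and bonds and differ only in configuration as drawn: 2 of 4 stereo elements differ; a stereocentre at a saturated ring carbon is drawn S in compound 2 and R in compound 3; a stereocentre at a saturated ring carbon is drawn R in compound 2 and S in compound 3. Within the data shown here, no step between the measured compounds is available, so nothing here shows how a change of configuration alone shifts the read-out. Compound 3 is expected to fall somewhat, the step of a number 8 percentage points lower from compound 2 to compound 3 (within the scatter) being estimated as small and possibly within the scatter. The estimate for compound 3 is 20%, ranging from 5% to 40%.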

Compound 3, a percentage reported as inhibition, at one concentration (the size of the read-out at that concentration, not a potency): 5.4%
The estimate for compound 3 lay 14.6 percentage points above the measured number; measured number inside the range.
By their numbers in this assay, from the lowest: compounds 3 and 1 (each within the scatter of the next); then compound 2.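

In this assay, within the data shown here, the pair gives the first step with atoms and bonds held fixed, and configuration alone moves the number: a number 22.6 percentage points lower from compound 2 to compound 3 (beyond the scatter). The earlier compounds shown here offered no such comparison. The step can be ascribed to the two saturated ring carbons whose drawn configurations swap, because nothing else separates the pair: the fact that compounds 2 and 3 differ only in the configuration as drawn

Both stereocentres change at once, so the compounds shown leave open which of them carries the step. Also open, as far as these compounds go, is whether it would persist with a hydroxymethyl group or a primary amide in place of the carboxylic acid.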